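This account rests on a few compounds, and the source may have more. Where it says the series, first, only, none or still open, it means among the compounds named here.

The study measured two sulfonamides in an ADME assay on HCT-116 cells (Homo sapiens) for cytotoxicity, read by CellTiter-Glo, with a stated time of 72 h; on this read-out higher numbers stand for weaker inhibition and lower numbers for stronger inhibition. Compound 1 `Cc1cc(C)c(S(=O)(=O)N2CCN(C3CN4CCC3CC4)CC2)c(C)c1` is one of them. In this assay compound 1 reports only a limit of > 5000 nM, and not a number, matching (the limit of > 5000 nM in this assay, at which 1 of the 2 values shown sits). Compound 2 `CC1CCN(C2CCN(S(=O)(=O)c3cccnc3Cl)CC2)CC1` is the other. In this assay compound 2 likewise reports only a limit of > 10000 nM, not a number, matching (the limit of > 10000 nM in this assay, at which 1 of the 2 values shown sits). For the measured compounds named here, both values shown are therefore limits, so compound 2 stands among compounds for which this assay gave no measurable inhibition, and no measured step between compound 1 and compound 2 can be stated beyond what the two limits show.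

Compound 3 `CC1CCN(C2CCN(S(=O)(=O)c3ccc(Cl)nc3)CC2)CC1` has not yet been measured in this assay. It differs from compound 2 in one place, (6-chloropyridin-3-yl in place of 2-chloropyridin-3-yl on a sulfonyl sulfur). Going by the values given here, with no measured step available, the expected step that the limit leaves unreadable from compound 2 to compound 3 is judged to be none beyond the scatter, and compound 3 is expected to return a limit as well. Compound 3 is estimated at 15000 nM in this assay, within an expected range from 5000 nM to 50000 nM.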

Compound 3, half-maximal inhibitory concentration: > 10000 nM
Compound 3: a limit, no number; the forecaster's own chance of this, stated with the estimate: 85%; the middle value lies beyond the limit too.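

In this assay compound 2 gives > 10000 nM, a limit and not a number. Compound 3 gives > 10000 nM, again a limit, so no step can be read between these two compounds. The compounds shown leave open whether 6-chloropyridin-3-yl and 2-chloropyridin-3-yl differ at all in this assay, and what numerical value either compound would give.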